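The source may hold more compounds than are shown below. What is called first, only, known or untested is meant among the compounds shown, and "the series" means these compounds.

Measured compounds and values in an assay on frontal cortex for displacement of a labelled ligand from corticotropin-releasing factor receptor 1 (Rattus norvegicus), with a stated time of 2 h; a lower number here means a stronger inhibitor, a higher number a weaker inhibitor:

Compound 1 `COc1nc(C)c(Nc2nc(Cl)cn([C@H](COC(=O)Nc3ccc(Cl)cc3)C3CC3)c2=O)cc1C`: 1.6 nM
Compound 2 `COc1nc(C)c(Nc2nc(Cl)cn([C@H](COC(=O)Nc3cccc(C#N)c3)C3CC3)c2=O)cc1C`: 1.3 nM

Compound 2 gives the lowest of the two numbers in this assay, its nearest neighbour being compound 1; the step of a 1.2-fold lower number from compound 1 to compound 2 (0.09 log units; within the scatter) is within the scatter, so the two cannot be ordered on these data.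

Compound 3 `COc1ccc(NC(=O)OC[C@H](C2CC2)n2cc(Cl)nc(Nc3cc(C)c(OC)nc3C)c2=O)c(C)n1` is not yet measured. It differs from compound 2 in one place: 6-methoxy-2-methylpyridin-3-yl in place of 3-cyanophenyl on an amide-type nitrogen. Going by the values given here, the only step recorded so far, a 1.2-fold lower number from compound 1 to compound 2 (0.09 log units; within the scatter), also swaps the aryl group on that amide-type nitrogen and did not move the number beyond the scatter. Among the compounds with values here, that step bears on the present change only loosely, since the entering group here is a pyridine ring with methoxy and methyl substituents rather than a carbon-only ring, and no compound with a heteroaromatic group at this position has been measured. On what is known, the carbamate aryl position tolerates exchange, so no step beyond the scatter is expected, with a wider range to allow for the untested ring type. The expected step of a 1.9-fold higher number from compound 2 to compound 3 (0.28 log units; within the scatter) is therefore small, and compound 3 is estimated at 2.5 nM, in the range 0.8 nM to 8 nM.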

Compound 3, half-maximal inhibitory concentration: 9.2 nM
For compound 3 the middle estimate is 3.7-fold (0.57 log units) below the measured one, outside the stated range (above it).
By their numbers in this assay, from the lowest: compounds 2 and 1 (each within the scatter of the next); then compound 3.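

In this assay the aryl group on the amide-type nitrogen proves not to be freely exchangeable: the change to 6-methoxy-2-methylpyridin-3-yl gives a 7.1-fold higher number from compound 2 to compound 3 (0.85 log units; beyond the scatter) and likewise a 5.8-fold higher number from compound 1 to compound 3 (0.76 log units; beyond the scatter), whereas 3-cyanophenyl and 4-chlorophenyl could not be told apart. The position therefore separates these two carbon-only rings from this substituted pyridine ring, although the loss is modest and compound 3 still gives 9.2 nM in this assay. No available measurement bears on what lies behind this rise.

Compound 3 brings in the ring nitrogen, the methoxy group and the methyl group together, so these compounds cannot show which of them carries the rise; an unsubstituted pyridin-3-yl group and a 6-methoxypyridin-3-yl group lacking the methyl would begin to separate them. On these data alone, it also remains open whether this nitrogen accepts a non-aromatic group such as cyclohexyl, since every group compared here is a six-membered aromatic ring.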